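A few compounds are considered here, and "the series" means these few. Any claim that something is new, unique, unknown or untested is made for them only; others in the source may bear on it.

Measured compounds:
compound 1 `Fc1cc(Cl)ccc1N1CCN(Cc2ccn3c(CC4CC4)nnc3c2C(F)(F)F)CC1`, > 10000 nM;
compound 2 `Fc1ccc(N2CCN(Cc3cc(C(F)(F)F)cn4c(CC5CC5)nnc34)CC2)c(F)c1`, > 10000 nM.

The study covers two measured compounds and one that has not yet been measured. In a functional assay on HEK293 cells for agonist activity at metabotropic glutamate receptor 1 (Homo sapiens), read by a luciferase reporter and cAMP accumulation (a higher number here means that more compound is needed for the effect, a lower number that less compound is needed), compound 1 gives > 10000 nM, which is a limit of the assay rather than a number. In this assay compound 2 likewise gives > 10000 nM, again a limit and not a number. Compound 1 therefore stands at the limit of > 10000 nM in this assay, at which 2 of the 2 values shown sit, so neither measured value offers a point from which a step could be counted.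

Compound 3 `Fc1ccccc1N1CCN(Cc2ccn3c(CC4CC4)nnc3c2C(F)(F)F)CC1` is the compound still to be measured. It differs from compound 1 by hydrogen in place of chloro on an aromatic carbon. For the measured compounds named here, no measured step matches this change. Since compound 1 sits at a limit, a change of only a hydrogen for a chloro group is expected to leave compound 3 at or near that same limit, with the expected step that the limit leaves unreadable from compound 1 to compound 3 being none beyond the scatter. Compound 3 is thus estimated at 15000 nM, within a range from 3000 nM to 60000 nM.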

Compound 3, half-maximal effective concentration: > 10000 nM
Compound 3 was reported as a limit; the forecaster's own chance of this, stated with the estimate: 85%; the middle value is on the limit's open side.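

Compound 1 and compound 3 both stand at a limit of the assay and not at a number, so no step can be read between them: the limit of > 10000 nM in this assay, at which 3 of the 3 values shown sit.

With no number from any compound shown in this assay, whether exchanging chloro for hydrogen changes the value at all stays open.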